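This account rests on a few compounds, and the source may have more. Where it says the series, first, only, none or still open, it means among the compounds named here.

Measured in a functional assay on MCF7 cells (Homo sapiens) for cytotoxicity, read by MTT assay, with a stated time of 72 h; a lower number here means a stronger inhibitor, a higher number a weaker inhibitor:

Compound 1 `CN(C)CCCCCn1c2c(c3ccccc31)C(=O)c1c[n+]([O-])c3ccccc3c1C2=O` gives 200 nM
Compound 2 `O=C1c2c[n+]([O-])c3ccccc3c2C(=O)c2c1c1ccccc1n2CCCCn1ccnc1` gives 130 nM
Compound 3 `O=C1c2c[n+]([O-])c3ccccc3c2C(=O)c2c1c1ccccc1n2CCN1CCCC1` gives 320 nM

Compound 3 cannot be told apart from compound 1, the gap being a 1.6-fold higher number from compound 1 to compound 3 (0.20 log units; within the scatter). Compound 2 lies clearly lower, with a 2.5-fold higher number from compound 2 to compound 3 (0.39 log units; beyond the scatter), and this is the only gap among the three that clears the scatter.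

Compound 4 `CCCCN1CCN(CCCCn2c3c(c4ccccc42)C(=O)c2c[n+]([O-])c4ccccc4c2C3=O)CC1` has not yet been measured. Its structure departs from compound 3 as follows: 2-(4-butylpiperazin-1-yl)ethyl in place of pyrrolidin-1-yl on a saturated chain carbon, two bonds along the chain from an aromatic nitrogen. In words, 2-(4-butylpiperazin-1-yl)ethyl stands in place of pyrrolidin-1-yl on a saturated chain carbon, two bonds along the chain from an aromatic nitrogen.

For the measured compounds named here, two measured steps concern that same place. Compound 2 carries 2-(1H-imidazol-1-yl)ethyl there, and read in reverse, a 2.5-fold higher number from compound 2 to compound 3 (0.39 log units; beyond the scatter) suggests that a substituted ethyl group in place of pyrrolidin-1-yl may lower the number. Compound 1 carries 3-(dimethylamino)propyl there, and a 1.6-fold higher number from compound 1 to compound 3 (0.20 log units; within the scatter) points the same way but stays within the scatter. Going by the values given here, no measured compound carries a piperazine ring, so the guidance is indirect and a small step towards a lower number is expected. The expected step is a 1.8-fold lower number from compound 3 to compound 4 (0.25 log units; within the scatter). For compound 4 the estimate is 180 nM, with an expected range from 60 nM to 520 nM.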

Compound 4, half-maximal inhibitory concentration: 6900 nM
Compound 4: middle estimate off by 38-fold (1.58 log units), on the low side, and the stated range ends below it.
By their numbers in this assay, from the lowest: compounds 2, 1 and 3 (each within the scatter of the next, the first and the last beyond it); then compound 4.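

In this assay, for the compounds shown here, the three earlier groups on this saturated chain had differed modestly at most, and 4-butylpiperazin-1-yl brings the first large change at this position, with a 22-fold higher number from compound 3 to compound 4 (1.33 log units; beyond the scatter), a 53-fold higher number from compound 2 to compound 4 (1.72 log units; beyond the scatter) and a 35-fold higher number from compound 1 to compound 4 (1.54 log units; beyond the scatter). The position therefore tolerates the earlier groups but not every amine-bearing group: compound 4 stands apart from compounds 1, 2 and 3, and it is the only one of the four with a six-membered non-aromatic ring with 2 hetero atoms. Nothing among the data shown accounts for the size of this change.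

The butyl group and the piperazine ring enter together in compound 4, so the compounds shown do not tell which of the two goes with the higher number. Going by these compounds, an unsubstituted piperazine or a 4-methylpiperazin-1-yl group on the same chain would separate the ring from the butyl group, while a piperidine would show whether the second ring nitrogen matters, and these remain open here.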